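Amide substituent series on a shared adenosine-derived core

The source may report more compounds than this note shows. Statements on the series, on what has been measured and on what is new or still open speak of the compounds shown alone.

Measured so far:
compound 1 `CNC(=O)[C@H]1O[C@@H](n2cnc3c(NC4CC4)nc(Cl)nc32)[C@H](O)[C@@H]1O` — 2.24 nM
compound 2 `CCNC(=O)[C@H]1O[C@@H](n2cnc3c(NC4CC4)nc(Cl)nc32)[C@H](O)[C@@H]1O` — 0.676 nM

In an assay on CHO cells for displacement of a labelled ligand from adenosine receptor A3 (Homo sapiens) (a lower number here means a stronger inhibitor, a higher number a weaker inhibitor), compound 2 holds the lowest of the two numbers; its nearest neighbour is compound 1, a step of a 3.3-fold lower number from compound 1 to compound 2 (0.52 log units; beyond the scatter). That single step, methyl in place of hydrogen on the chain at the amide-type nitrogen, is the only one bearing on the next change. Compound 3 `O=C(NC1CC1)[C@H]1O[C@@H](n2cnc3c(NC4CC4)nc(Cl)nc32)[C@H](O)[C@@H]1O` carries cyclopropyl in place of ethyl on an amide-type nitrogen. Going by the values given here, one added carbon and the ring make a larger group than the one step covers, so the expectation is a step of a 1.1-fold lower number from compound 2 to compound 3 (0.05 log units; within the scatter), with compound 3 estimated at 0.6 nM, range 0.2 nM to 2 nM.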

Compound 3, inhibition constant: 5.62 nM
Estimate against measurement, compound 3: 9.4-fold (0.97 log units) below, and the stated range ends below it.
By their numbers in this assay, from the lowest: compound 2; then compound 1; then compound 3.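

At the amide-type nitrogen, the gain from methyl to ethyl does not carry over to cyclopropyl: in this assay the change runs the other way, with an 8.3-fold higher number from compound 2 to compound 3 (0.92 log units; beyond the scatter) beyond the earlier step in size. Cyclopropyl also falls behind methyl, with a 2.5-fold higher number from compound 1 to compound 3 (0.40 log units; beyond the scatter) placing compound 3 highest of the three, so the number does not simply fall as the group grows. No supporting data explain this reversal.

On these data alone, whether the ring or the added carbon drives the rise remains open. A propyl or isopropyl group on the same nitrogen would separate the two.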